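Notes on the anilide aryl group: compound 2 to compound 4

The source may hold more compounds than are shown below. What is called first, only, known or untested is meant among the compounds shown, and "the series" means these compounds.

Measured in a functional assay on T47D cells (Homo sapiens) for inhibition, read by CCK-8 assay, with a stated time of 72 h, tested at 10 uM; on this read-out higher numbers stand for more inhibition of growth at the one concentration tested and lower numbers for less inhibition of growth:
compound 1, `CN(C)C(=O)c1cc2cnc(Nc3ccc(NC(=O)C4(C(=O)Nc5ccc(F)cc5)CC4)cc3F)nc2n1C1CCCC1`, gives 67.9%
compound 2, `CN(C)C(=O)c1cc2cnc(Nc3ccc(NC(=O)C4(C(=O)Nc5cccc(Cl)c5)CC4)cc3)nc2n1C1CCCC1`, gives 92.6%
compound 3, `CN(C)C(=O)c1cc2cnc(Nc3ccc(N)cn3)nc2n1C1CCCC1`, gives 61.1%

Compound 2 holds the highest of the three numbers. Its nearest neighbour is compound 1, whose value lies lower by an amount beyond the usual scatter; the furthest is compound 3, lower still and likewise beyond the scatter. Among the measured compounds shown here, compounds 1 and 3 each differ from compound 2 in more than one place, so no single-change step between measured compounds is available, and the three values only set the spread within which the series has been seen so far.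

Compound 4, `CN(C)C(=O)c1cc2cnc(Nc3ccc(NC(=O)C4(C(=O)Nc5ccc(C(F)(F)F)cc5)CC4)cc3)nc2n1C1CCCC1`, has not yet been measured. It differs from compound 2 in one place: 4-(trifluoromethyl)phenyl in place of 3-chlorophenyl on an amide-type nitrogen. Compound 1, which also carries an amide-linked aryl group but with further changes elsewhere, gives 67.9%, the only other measured point with this part of the molecule present.

For the measured compounds named here, with no measured step to lean on, the step in this assay is estimated at a number 8.6 percentage points lower from compound 2 to compound 4 (within the scatter), a modest decrease that may yet fall within the scatter. Compound 4 is therefore expected to give 84%, with a range from 62% to 96%.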

Compound 4, percent growth inhibition at one concentration: 94.9%
The estimate for compound 4 lay 10.9 percentage points below the measured number, and the stated range covers the measured number.
By their numbers in this assay, from the lowest: compounds 3 and 1 (each within the scatter of the next); then compounds 2 and 4 (each within the scatter of the next).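

In this assay, among the compounds shown here, the first single-change step reads a number 2.3 percentage points higher from compound 2 to compound 4 (within the scatter), so 4-(trifluoromethyl)phenyl and 3-chlorophenyl on the amide-type nitrogen give numbers within the scatter of each other. This place in the molecule therefore carries either aryl group, with 10 heavy atoms in one and 7 in the other, and with fluorine in one and chlorine in the other, without a difference that this read-out can resolve at the one concentration tested. No measurement available here bears on why the two groups read alike.

Compound 1 differs from compound 2 in more than one place, so the part played by its anilide aryl group alone cannot be read from the numbers shown. Still open, as far as these compounds go, is whether this place would carry an aryl group with a methoxy, a carboxylic acid or an amine on the ring, or a pyridine ring in place of the phenyl ring, and whether compound 2 and compound 4 would separate in a read-out taken over a range of concentrations.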